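Substituent exchange at the aromatic carbon of the shared core

The compounds below may be only part of what the source reports. "The series", "measured", "known", "first", "only" and "open" are said of these compounds alone.

Compound 1 `C/C(=N\OCC(=O)O)c1ccc(C2CC2)cc1` is read in a functional assay on the whole organism for inhibition, with Rattus norvegicus as the target, read by paw edema, with stated times of 1 h and 3 h, at a dose of 50 mg/kg by the oral route; a lower number here means less inhibition, a higher number more inhibition at the dose given (going by the name of the read-out). In this assay compound 1 reaches only the assay limit, giving < 20%. Compound 2 `CSc1ccc(/C(C)=N/OCC(=O)O)cc1` carries methylsulfanyl in place of cyclopropyl on an aromatic carbon; in this assay compound 2 also sits at the limit, with < 20%. Compound 3 `C/C(=N\OCC(=O)O)c1ccc(S(C)(=O)=O)cc1` carries methylsulfonyl on that aromatic carbon and gives 20% in this assay. The step that the two limits leave unreadable from compound 1 to compound 2 cannot be sized, and the steps of a number no lower from compound 1 to compound 3 (the limit leaves the size open) and a number no lower from compound 2 to compound 3 (the limit leaves the size open) are open in size because the limit of < 20% in this assay, at which 2 of the 3 values shown sit, holds the starting value in each case. So far no exchange at this aromatic carbon has produced a reading that stands clear of the limit.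

Compound 4 `C/C(=N\OCC(=O)O)c1ccc(N(C)C)cc1` differs from compound 1 by dimethylamino in place of cyclopropyl on an aromatic carbon. Going by the values given here, no measured pair covers this exchange; the three steps above bear on it only in that each of them left the read-out at or near the limit. The step that the limit leaves unreadable from compound 1 to compound 4 is therefore expected to be none beyond the scatter. Compound 4 is estimated at 15%, within a range from 5% to 30%, and is expected most likely to be reported as a limit again.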

Compound 4, a percentage reported as inhibition, in the whole organism at one dose (the size of the read-out at that dose, not a potency): < 20%
Compound 4 was reported as a limit; the forecaster's own chance of this, stated with the estimate: 65%; the middle value lies beyond the limit too.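

In this assay compound 4 gives < 20%, which is a limit of the assay. Dimethylamino has the same count of heavy atoms as cyclopropyl, but it has no ring and brings one hydrogen-bond acceptor, so the exchanges at this aromatic carbon now include an open nitrogen group, and the read-out still stays at the limit. The only step with a direction is a number no higher from compound 3 to compound 4 (the limit leaves the size open); the other steps to compound 4 cannot be read, because most values of the series rest on one reading: the limit of < 20% in this assay, at which 3 of the 4 values shown sit.

On these data alone, what lies under the limit for compound 1, compound 2 and compound 4 stays unknown, so these three groups cannot be ranked against one another. As far as these compounds go, whether a sulfonamide or a longer alkyl chain on this aromatic carbon would give a reading that stands clear of the limit remains open.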